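A Dimethylaminopropyl Chain on the Core Nitrogen

This account rests on a few compounds, and the source may have more. Where it says the series, first, only, none or still open, it means among the compounds named here.

Measured so far:
- compound 1, `Cc1nn(C)c2c1C(c1ccccc1)=NCCN2`: 2.5 mg/kg
- compound 2, `Cc1nn(C)c2c1C(c1ccccc1)=NCCN2CCCN(C)C`: > 10 mg/kg, a limit of the assay rather than a number
- compound 3, `Cc1nn(C)c2c1C(c1cccc(F)c1)=NCCN2`: 2.5 mg/kg

All three were tested in a functional assay on the whole organism for positive allosteric modulation, with Rattus norvegicus as the target; on this read-out higher numbers stand for an effect only at larger amounts of compound and lower numbers for an effect already at smaller amounts. Compound 1 gives 2.5 mg/kg in this assay. For compound 2 the reported > 10 mg/kg is a limit of the assay and not a number. The change from compound 1 to compound 2 is 3-(dimethylamino)propyl in place of hydrogen on a nitrogen on an aromatic ring in a ring, and it produces an at least 4.0-fold higher number from compound 1 to compound 2 (0.60 log units; beyond the scatter); how far the true step goes beyond that is hidden because of the limit of > 10 mg/kg in this assay, at which 1 of the 3 values shown sits. Compound 3 gives 2.5 mg/kg in this assay. Its difference from compound 1 is fluoro in place of hydrogen on an aromatic carbon, and this gives no change at the digits printed from compound 1 to compound 3 (within the scatter), so compound 3 sits level with compound 1.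

Compound 4, `Cc1nn(C)c2c1C(c1cccc(F)c1)=NCCN2CCCN(C)C`, has not been measured. It differs from compound 3 by 3-(dimethylamino)propyl in place of hydrogen on a nitrogen on an aromatic ring in a ring. This is the same kind of change as from compound 1 to compound 2; the two places differ only in that the ring atom three ring bonds away bears a 3-fluorophenyl group in compound 3 and a phenyl group in compound 1. The step from compound 3 to compound 4 is expected to be about a 6.0-fold higher number from compound 3 to compound 4 (0.78 log units; beyond the scatter), resting on the earlier step of an at least 4.0-fold higher number from compound 1 to compound 2 (0.60 log units; beyond the scatter). Compound 4 is therefore estimated at 15 mg/kg, with a likely range from 6 mg/kg to 40 mg/kg, and a limit rather than a number would not be surprising.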

Compound 4, minimum effective dose: > 10 mg/kg
Compound 4 gave a limit, no number (the forecaster's own chance of this, stated with the estimate: 65%); the middle value does not contradict the limit.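

In this assay compound 4 gives > 10 mg/kg, which is a limit of the assay and not a number. Putting the 3-(dimethylamino)propyl chain on the nitrogen of the core that bears a 3-fluorophenyl group gives an at least 4.0-fold higher number from compound 3 to compound 4 (0.60 log units; beyond the scatter), so the change pushes the number up, meaning a larger dose is needed for an effect, on this core as it does on the core of compound 1, and in these two cases it carries over in direction. It does not show that the step has the same size on both cores, and the fluoro step from compound 2 to compound 4 cannot be read at all, since both of those results are limits: the same change on two cores in this assay, an at least 4.0-fold higher number (0.60 log units; beyond the scatter) from compound 1 to compound 2 and an at least 4.0-fold higher number (0.60 log units; beyond the scatter) from compound 3 to compound 4; the limit leaves it open whether they differ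

The compounds shown leave open whether the whole chain or only part of it goes with the higher number, as a plain methyl on that nitrogen, a shorter chain or a longer chain could help to separate these, as could a chain ending in a carboxylic acid instead of the dimethylamino group. They also leave open whether any group on that nitrogen keeps the number level with compound 1 and compound 3.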